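Halogen swap on the aryl ring of compound 2

The source may hold more compounds than are shown below. What is called first, only, known or untested is meant among the compounds shown, and "the series" means these compounds.

Measured compounds:
compound 1, `NC1=NC2(CCSCC2)N(OCCCOc2cccc(Cl)c2Cl)C(N)=N1`, 1 nM
compound 2, `NC1=NC2(CCOCC2)N(OCCCOc2ccc(Cl)cc2)C(N)=N1`, 360 nM
compound 3, `NC1=NC2(CCSCC2)N(OCCCOc2ccc(Cl)cc2)C(N)=N1`, 580 nM

In a functional assay on A549 cells (Homo sapiens) for antiproliferative activity, read by MTT assay, with a stated time of 72 h (on this read-out higher numbers stand for weaker inhibition and lower numbers for stronger inhibition), compound 2 gives 360 nM, the second highest of the three numbers; compound 3 sits nearest with 580 nM, within the scatter, while compound 1 stands far off with 1 nM. Among the measured compounds shown here, the only single-point step measured is a 580-fold higher number from compound 1 to compound 3 (2.76 log units; beyond the scatter), a change of the whole substitution pattern on the aryl ring.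

Compound 4, `NC1=NC2(CCOCC2)N(OCCCOc2ccc(Br)cc2)C(N)=N1`, differs from compound 2 by bromo in place of chloro on an aromatic carbon. For the measured compounds named here, no measured step exchanges one halogen for another at the same position, so the step from compound 2 to compound 4 has no direct precedent. Going by the values given here, the one large step concerns a different change and bears on this only loosely. Among the compounds with values here, with no comparable step on record, the expectation is a step of no size beyond the scatter: a 1.2-fold lower number from compound 2 to compound 4 (0.08 log units; within the scatter).

Compound 4 is therefore expected to give about 300 nM, with a range from 100 nM to 900 nM.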

Compound 4, half-maximal inhibitory concentration: 280 nM
Compound 4: middle estimate off by 1.1-fold (0.03 log units), on the high side; the measured number falls inside the stated range.
By their numbers in this assay, from the lowest: compound 1; then compounds 4, 2 and 3 (each within the scatter of the next, the first and the last beyond it).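

In this assay, bromo in place of chloro on an aromatic carbon, para to a large group, gives a 1.3-fold lower number from compound 2 to compound 4 (0.11 log units; within the scatter). Among the compounds shown here, this is the first direct exchange of one halogen for another at a single position, and the earlier large step, which altered the whole substitution pattern on the aryl ring, could not show it. On the core of compound 2, the 4-chlorophenoxy and 4-bromophenoxy ends therefore cannot be told apart in this read-out, and no supporting data on hand bear on this result.

Fluoro, methoxy, an amine or a carboxylic acid at this position remain open. Also open, on these data alone, is how bromo would read in the dichlorinated aryl group of compound 1, which gives 1 nM.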